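A few compounds are considered here, and "the series" means these few. Any claim that something is new, unique, unknown or untested is made for them only; others in the source may bear on it.

Three compounds have been measured in a functional assay on HepG2 cells (Homo sapiens) for antiproliferative activity, read by MTT assay, with a stated time of 48 h; a higher number here means a weaker inhibitor, a lower number a stronger inhibitor:

Compound 1, `O=C(Nc1cccc(CNc2nccnc2Cl)c1)Nc1ccccc1F`, gives 10500 nM.
Compound 2, `O=C(Nc1cccc(CNc2nccnc2Cl)c1)NC1CCCCC1`, reaches only a limit of the assay, > 40000 nM.
Compound 3, `Cc1ccccc1NC(=O)Nc1cccc(CNc2nccnc2Cl)c1`, gives 15300 nM.

Compound 3 and compound 1 give numbers that lie within the scatter of each other: a 1.5-fold higher number from compound 1 to compound 3 (0.16 log units; within the scatter). For compound 2 the value is the limit of > 40000 nM in this assay, at which 1 of the 3 values shown sits, a limit rather than a number. Compound 4, `O=C(Nc1cccc(Cl)c1)Nc1cccc(CNc2nccnc2Cl)c1`, has not been measured. It differs from compound 3 in one place: 3-chlorophenyl in place of 2-methylphenyl on an amide-type nitrogen. Two kinds of measured step bear on this change. Swapping one aromatic group for another on that nitrogen was small: a 1.5-fold higher number from compound 1 to compound 3 (0.16 log units; within the scatter). Swapping an aromatic group for cyclohexyl on the same nitrogen was larger, an at least 3.8-fold higher number from compound 1 to compound 2 (0.58 log units; beyond the scatter) and an at least 2.6-fold lower number from compound 2 to compound 3 (0.41 log units; beyond the scatter), but compound 4 keeps an aromatic group there. Within the data shown here, no measured pair sets a 3-chlorophenyl against a 2-methylphenyl, so the step in this assay is expected to stay within the scatter, with no firm direction. Compound 4 is therefore expected to give about 12000 nM, between 5000 nM and 35000 nM. The estimate for compound 4 means an expected step of a 1.3-fold lower number from compound 3 to compound 4 (0.11 log units; within the scatter).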

Compound 4, half-maximal inhibitory concentration: 9140 nM
Compound 4: middle estimate off by 1.3-fold (0.12 log units), on the high side; measured number inside the range.
By their numbers in this assay, from the lowest: compounds 4, 1 and 3 (each within the scatter of the next). At a limit, above all of these: compound 2.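

In this assay, compound 4 puts a third aromatic group on the amide-type nitrogen, now carrying chlorine where the earlier aromatic groups carried methyl or fluoro, and the numbers remain within the scatter of each other (a 1.7-fold lower number from compound 3 to compound 4 (0.22 log units; within the scatter); a 1.1-fold lower number from compound 1 to compound 4 (0.06 log units; within the scatter)). Among compounds 1, 3 and 4, 2-fluorophenyl, 2-methylphenyl and 3-chlorophenyl therefore cannot be told apart in this measurement, whereas the step from the cyclohexyl group is now seen with a third aromatic partner and lies beyond the scatter (an at least 4.3-fold lower number from compound 2 to compound 4 (0.64 log units; beyond the scatter)). Compound 2 remains a limit and not a number: the limit of > 40000 nM in this assay, at which 1 of the 4 values shown sits.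

The compounds shown leave open whether the element or its place on the ring matters, since 2-chlorophenyl and 3-methylphenyl would be needed to separate the two. They also leave open how the number would respond to a plain phenyl, a pyridine ring, or an aromatic ring bearing an amine or a carboxylic acid.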